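The source may report more compounds than this note shows. Statements on the series, on what has been measured and on what is new or still open speak of the compounds shown alone.

In an assay on HEK293 cells for inhibition of neurogenic locus notch homolog protein 1 (Homo sapiens), read by a luciferase reporter and resazurin assay, with a stated time of 16 h (a higher number here means a weaker inhibitor, a lower number a stronger inhibitor), compound 3 `CC1=C(C(=O)OCC2CCN(C(=O)OC(C)(C)C)CC2)C(c2ccc3c(c2)OCCO3)C2=C(CC(C)(C)CC2=O)N1` gives 1520 nM. Of the two measured numbers this is the lower one, which means the stronger inhibition. Compound 1 `CC1=C(C(=O)OC2CCCCC2)C(c2ccc3c(c2)OCCO3)C2=C(CC(C)(C)CC2=O)N1` shares the core of compound 3 but carries a different ester group. In this assay compound 1 gives 12300 nM. The gap between compound 3 and compound 1 lies beyond the usual scatter of repeated measurements. For the measured compounds named here, compound 2 `CC1=C(C(=O)O[C@H](CC#N)c2ccccc2)C(c2cccc(Br)c2)C2=C(CC(C)(C)CC2=O)N1` gives > 10000 nM in this assay, which is a limit of the assay rather than a measured number; it is the single value that sits at the limit of > 10000 nM in this assay, at which 1 of the 3 values shown sits.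

Compound 4 `CC1=C(C(=O)OCC2CCN(C(=O)OC(C)(C)C)CC2)C(c2ccc(-c3ccccc3)cc2)C2=C(CC(C)(C)CC2=O)N1` has not yet been measured. It differs from compound 3 in one place: 4-phenylphenyl in place of 2,3-dihydro-1,4-benzodioxin-6-yl on a saturated ring carbon. Going by the values given here, no measured pair shows this particular exchange. Among the compounds with values here, there is no measured step to lean on, and the expectation rests on the position of compound 3 alone. The change is expected to shift the number only a little, if at all, so the step from compound 3 to compound 4 is estimated as a 1.6-fold higher number from compound 3 to compound 4 (0.22 log units; within the scatter), within or close to the scatter. On that basis compound 4 is expected to give about 2500 nM in this assay, with a plausible range from 600 nM to 10000 nM.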

Compound 4, half-maximal inhibitory concentration: > 10000 nM
Compound 4: no number, only a limit; the forecaster's own chance of this, stated with the estimate: 20%; middle value at least 4.0-fold (0.60 log units) from the limit.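

The group on this saturated ring carbon matters in this assay: with the ester and the rest of the core unchanged, 4-phenylphenyl in place of 2,3-dihydro-1,4-benzodioxin-6-yl gives an at least 6.5-fold higher number from compound 3 to compound 4 (0.81 log units; beyond the scatter). This is the first step among the compounds shown that changes a single place, and it shows that these two groups are not interchangeable at this position, although both are attached through an aromatic ring. The entering group consists of aromatic rings of carbon only, whereas the leaving group holds oxygen atoms in a non-aromatic ring, and the full size of the step stays unknown, as compound 4 gives a limit of the assay and not a number: the limit of > 10000 nM in this assay, at which 2 of the 4 values shown sit.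

This one step cannot say which difference between the two groups carries the change, and a plain phenyl or a 4-methoxyphenyl group on the same carbon would help to separate them. Also open, as far as these compounds go, is whether the same exchange has a similar effect when the core carries the ester of compound 1.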